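This account rests on a few compounds, and the source may have more. Where it says the series, first, only, none or still open, it means among the compounds named here.

Measured so far in a functional assay on CHO cells for antagonist activity at C-C chemokine receptor type 4 (Homo sapiens), read by GTPgammaS binding; on this read-out lower numbers stand for stronger inhibition and higher numbers for weaker inhibition:
Compound 1, `CC(=O)NCc1cccc(Cn2nc(NS(=O)(=O)c3ccc(Cl)s3)c3c(F)cccc32)c1`, 79.4 nM
Compound 2, `CC(=O)NCc1cccc(Cn2nc(NS(=O)(=O)c3ccc(Cl)s3)c3c(O)cccc32)c1`, 12.6 nM
Compound 3, `CC(=O)NCc1cccc(Cn2nc(NS(=O)(=O)c3ccc(Cl)s3)c3c(C(C)O)cccc32)c1`, 20 nM

Compound 3 sits second highest of the three numbers: against compound 2 it differs by a 1.6-fold higher number from compound 2 to compound 3 (0.20 log units; within the scatter), which stays within the scatter, while against compound 1 it shows a 4.0-fold lower number from compound 1 to compound 3 (0.60 log units; beyond the scatter), a step beyond it. Compound 4 `CC(=O)NCc1cccc(Cn2nc(NS(=O)(=O)c3ccc(Cl)s3)c3c(C(C)(C)O)cccc32)c1` differs from compound 3 by methyl in place of hydrogen on a saturated chain carbon bound to an aromatic carbon, an oxygen on a saturated carbon and a saturated chain carbon. Among the compounds with values here, no measured step changes this position in the same way. The step from compound 2 to compound 3, which also alters the group at this place, was small, and the larger steps from compound 1 concern the loss of fluoro rather than growth of the hydroxyalkyl chain. Compound 4 is therefore expected to move by about no change at the digits printed from compound 3 to compound 4 (within the scatter), which is no shift beyond the scatter, and is estimated at 20 nM with a range from 8 nM to 50 nM.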

Compound 4, half-maximal inhibitory concentration in the C-C chemokine receptor type 4 assay: 100 nM
For compound 4 the middle estimate is 5.0-fold (0.70 log units) below the measured one, and the stated range ends below it.
By their numbers in the C-C chemokine receptor type 4 assay, from the lowest: compounds 2 and 3 (each within the scatter of the next); then compounds 1 and 4 (each within the scatter of the next).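

In the C-C chemokine receptor type 4 assay, growth at this carbon is not neutral, unlike the earlier change from hydroxy to 1-hydroxyethyl: one added methyl gives a 5.0-fold higher number from compound 3 to compound 4 (0.70 log units; beyond the scatter). In the C-C chemokine receptor type 4 assay, compound 4 gives 100 nM. The 1-hydroxy-1-methylethyl group gives a 7.9-fold higher number from compound 2 to compound 4 (0.90 log units; beyond the scatter), yet only a 1.3-fold higher number from compound 1 to compound 4 (0.10 log units; within the scatter), so the gain seen with 1-hydroxyethyl over fluoro does not carry over to it. In a physicochemical assay for solubility, read by chemiluminescence, measured as kinetic solubility (a lower number here means a less soluble compound, a higher number a more soluble compound), compound 3 gives a limit, >= 208 ug/mL. In the physicochemical assay, compound 4 also gives a limit, >= 159 ug/mL. Both values in the physicochemical assay are limits, so that step cannot be read, and nothing given bears on the cause of the shift. The compounds shown leave open whether an ethyl on this carbon would give the same shift as methyl. They also leave open how an amine in place of the hydroxy would read.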